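The source may report more compounds than this note shows. Statements on the series, on what has been measured and on what is new or still open speak of the compounds shown alone.

Compound 1 `CCNC(=O)c1noc(-c2cc(C(C)C)c(O)cc2O)c1-c1cc(COCC(N)=O)no1` gives 97 nM
Compound 2 `CCNC(=O)c1noc(-c2cc(C(C)C)c(O)cc2O)c1-c1cc(CN2CCCC2)no1` gives 51 nM
Compound 3 `CCNC(=O)c1noc(-c2cc(C(C)C)c(O)cc2O)c1-c1cc(C(=O)OCC)no1` gives "not determined" (no result reported)

These values come from a functional assay on HCT-116 cells (Homo sapiens) for inhibition; on this read-out higher numbers stand for weaker inhibition and lower numbers for stronger inhibition. Compound 3 has no number, so it offers no baseline from which to measure a step. Compound 4 `CCNC(=O)c1cc(-c2c(C(=O)NCC)noc2-c2cc(C(C)C)c(O)cc2O)on1` carries ethylamino in place of ethoxy on a carbonyl carbon, turning ethoxycarbonyl into ethylcarbamoyl: ethylamino in place of ethoxy on a carbonyl carbon. Going by the values given here, the only measured step, a 1.9-fold lower number from compound 1 to compound 2 (0.28 log units; within the scatter), changes a different group, on a saturated chain carbon, and stays within the scatter. It bears on this change only indirectly, so no size or direction of step can be expected from compound 3. The expectation therefore rests on the two measured values, and compound 4 is expected to fall near them. For compound 4 the estimated value is 70 nM, with an expected range of 22 nM to 220 nM.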

Compound 4, half-maximal inhibitory concentration: 14 nM
Estimate against measurement, compound 4: 5.0-fold (0.70 log units) above; measured number below the stated range.
By their numbers in this assay, from the lowest: compound 4; then compounds 2 and 1 (each within the scatter of the next).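

In this assay ethylcarbamoyl on this aromatic carbon stands apart from the other two measured groups, with a 3.6-fold lower number from compound 2 to compound 4 (0.56 log units; beyond the scatter) and with a 6.9-fold lower number from compound 1 to compound 4 (0.84 log units; beyond the scatter) while the earlier step between those two groups stayed within the scatter. Compound 3 has no value, so the step from ethoxycarbonyl to ethylcarbamoyl cannot be read. Nothing measured here accounts for the difference. Still open, on these data alone, is whether the amide hydrogen or the ethyl chain matters more, and how a carboxylic acid or a propylcarbamoyl group on this carbon would compare.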